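The compounds below may be only part of what the source reports. "The series", "measured", "known", "first", "only" and "open" are said of these compounds alone.

Compound 1 `Nc1ccccc1NC(=O)c1ccc(CSC(=S)N2CCN(c3ccccc3)CC2)cc1` gives 2330 nM
Compound 2 `Nc1ccccc1NC(=O)c1ccc(CSC(=S)N2CCN(c3ccc(F)cc3)CC2)cc1` gives 2730 nM
Compound 3 `Nc1ccccc1NC(=O)c1ccc(CSC(=S)N2CCc3cc(Cl)ccc32)cc1` gives 3210 nM

In a functional assay on HCT-116 cells (Homo sapiens) for antiproliferative activity, read by CCK-8 assay, with a stated time of 72 h (on this read-out higher numbers stand for weaker inhibition and lower numbers for stronger inhibition), compound 2, at 2730 nM in the middle of the three numbers, stays within the scatter of both compound 1 and compound 3. Compound 4 `Nc1ccccc1NC(=O)c1ccc(CSC(=S)N2CCN(c3ccncc3)CC2)cc1` has pyridin-4-yl in place of 4-fluorophenyl on an amine nitrogen in a ring is the full difference. Going by the values given here, the only measured step on this group is a 1.2-fold higher number from compound 1 to compound 2 (0.07 log units; within the scatter) and stays within the scatter. Among the compounds with values here, no measured compound carries pyridin-4-yl, so that evidence is indirect. A shift beyond the scatter is therefore not expected, though the range is kept wide. The expected step is a 1.1-fold lower number from compound 2 to compound 4 (0.04 log units; within the scatter) and lies within the scatter. For compound 4 the estimated value is 2500 nM in this assay with an expected range from 1100 nM to 5500 nM here.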

Compound 4, half-maximal inhibitory concentration: 540 nM
The estimate for compound 4 lay 4.6-fold (0.67 log units) above the measured number; measured number below the stated range.
By their numbers in this assay, from the lowest: compound 4; then compounds 1, 2 and 3 (each within the scatter of the next).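

In this assay the group on this amine nitrogen in a ring does change the number: pyridin-4-yl in place of 4-fluorophenyl gives a 5.1-fold lower number from compound 2 to compound 4 (0.70 log units; beyond the scatter) and pyridin-4-yl in place of phenyl gives a 4.3-fold lower number from compound 1 to compound 4 (0.63 log units; beyond the scatter). Going by these compounds alone, both steps lie beyond the scatter, whereas the fluoro step among the earlier compounds stayed within it. Nothing measured here explains this change. The compounds shown leave open whether pyridin-3-yl, pyrimidin-5-yl or a saturated group such as cyclohexyl on this nitrogen would give a similar step.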